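The source may report more compounds than this note shows. Statements on the series, on what has been measured and on what is new or still open speak of the compounds shown alone.

Working notes on the series.

The compounds share the core of compound 1 `Cn1cc(C(N)=O)c2c(N)ncnc21`. In a functional assay on KB cells (Homo sapiens) for cytotoxicity (a lower number here means a stronger inhibitor, a higher number a weaker inhibitor), compound 1 gives only a limit of the assay, > 100000 nM. Compound 2 `Cn1cc(C#N)c2c(N)ncnc21` carries the change (cyano in place of carbamoyl on an aromatic carbon). In this assay compound 2 likewise reaches only a limit, > 100000 nM. Compound 3 `Cc1ccccc1Cn1cc(C(N)=O)c2c(N)ncnc21` differs from compound 1 by 2-methylphenyl in place of hydrogen on a saturated chain carbon bound to an aromatic nitrogen. In this assay compound 3 also returns only a limit, > 100000 nM. The steps a step that the two limits leave unreadable from compound 1 to compound 2 and a step that the two limits leave unreadable from compound 1 to compound 3 therefore give no readable size, because of the limit of > 100000 nM in this assay, at which 3 of the 3 values shown sit.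

Compound 4 `Cc1ccccc1Cn1cc(C#N)c2c(N)ncnc21` is not yet measured in this assay. It differs from compound 3 by cyano in place of carbamoyl on an aromatic carbon, the same kind of change as that from compound 1 to compound 2, though here the ring atom bears a group of 8 heavy atoms rather than a methyl group. Compound 4 is expected to sit at a limit as well, with a step estimated at a step that the limit leaves unreadable from compound 3 to compound 4, because the limit of > 100000 nM in this assay, at which 3 of the 3 values shown sit, covers every measured compound of the series. For compound 4 the estimate in this assay is 150000 nM, with the expected range running from 50000 nM to 500000 nM.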

Compound 4, half-maximal inhibitory concentration: > 100000 nM
Compound 4 ended at the assay's limit; the forecaster's own chance of this, stated with the estimate: 85%; the middle value does not contradict the limit.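

In this assay compound 4 gives > 100000 nM, which is a limit of the assay and not a number. The step between compound 3 and compound 4 therefore cannot be read: the limit of > 100000 nM in this assay, at which 4 of the 4 values shown sit.

The compounds shown leave open whether cyano in place of carbamoyl, or any other change in the series, alters the result in this assay at all.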